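The source may report more compounds than this note shows. Statements on the series, on what has been measured and on what is new or still open speak of the compounds shown alone.

In a functional assay on HEL cells (Homo sapiens) for cytotoxicity, read by microscopy (a lower number here means that less compound is tolerated, a higher number that more compound is tolerated), compound 3, with the structure `Cc1cn([C@@H]2O[C@H](CO[Si](C)(C)C(C)(C)C)[C@@]3(OS(=O)(=O)C=C3NC(=O)c3ccccc3)[C@H]2O[Si](C)(C)C(C)(C)C)c(=O)n(C)c1=O`, gives >= 3200 nM, which is a limit of the assay and not a measured number. Two related compounds have been examined in the same way. Compound 1, with the structure `CC(=O)NC1=CS(=O)(=O)O[C@@]12[C@@H](CO[Si](C)(C)C(C)(C)C)O[C@@H](n1cc(C)c(=O)n(C)c1=O)[C@@H]2O[Si](C)(C)C(C)(C)C`, gives >= 80000 nM, again a limit of the assay. Compound 2, with the structure `COC(=O)NC1=CS(=O)(=O)O[C@@]12[C@@H](CO[Si](C)(C)C(C)(C)C)O[C@@H](n1cc(C)c(=O)n(C)c1=O)[C@@H]2O[Si](C)(C)C(C)(C)C`, gives >= 50000 nM, also a limit of the assay. The steps a step that the two limits leave unreadable from compound 1 to compound 3 and a step that the two limits leave unreadable from compound 2 to compound 3 are the ones that touch compound 3, and neither can be read, since (the limit of >= 3200 nM in this assay, at which 1 of the 3 values shown sits), the limit of >= 50000 nM in this assay, at which 1 of the 3 values shown sits, and the limit of >= 80000 nM in this assay, at which 1 of the 3 values shown sits, each hold one of the three values. Compound 4, with the structure `Cc1cn([C@@H]2O[C@H](CO[Si](C)(C)C(C)(C)C)[C@@]3(OS(=O)(=O)C=C3NCCC(N)=O)[C@H]2O[Si](C)(C)C(C)(C)C)c(=O)n(C)c1=O`, differs from compound 3 by 2-carbamoylethyl in place of benzoyl on an amine nitrogen. Going by the values given here, no measured step bears directly on this change, and the limits around compound 3 leave the size of any step unreadable. The expected step that the limit leaves unreadable from compound 3 to compound 4 therefore cannot be set beyond the scatter in either direction, and the most likely outcome is another limit. Compound 4 is expected to give 20000 nM in this assay, with a range from 3200 nM to 100000 nM.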

Compound 4, minimum cytotoxic concentration: >= 80000 nM
Compound 4 gave a limit, no number (the forecaster's own chance of this, stated with the estimate: 85%); middle value at least 4.0-fold (0.60 log units) from the limit.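

In this assay compound 4 gives >= 80000 nM, which is a limit of the assay and not a number. Going by these compounds alone, no step from compound 1, compound 2 or compound 3 to compound 4 can be read. The compounds shown leave open where the minimum cytotoxic concentration of any of the four lies, and whether the group on the amine nitrogen changes it at all.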